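Cyclohexyl for Cyclopentyl on a Fluorinated Core: Expected Tolerance

The source may report more compounds than this note shows. Statements on the series, on what has been measured and on what is new or still open speak of the compounds shown alone.

Compound 1 `[O-][n+]1nc(NC2CCCC2)[n+]([O-])c2ccccc21` gives 10 ug/mL in an ADME assay on Vero cells (Chlorocebus sabaeus) for cytotoxicity, read by CellTiter-Glo, with a stated time of 72 h; a higher number here means that more compound is tolerated, a lower number that less compound is tolerated. Compound 2 `[O-][n+]1nc(NC2CCCCC2)[n+]([O-])c2ccccc21` differs from compound 1 by cyclohexyl in place of cyclopentyl on a nitrogen on an aromatic ring and in this assay compound 2 gives 8.9 ug/mL, so that the step of a 1.1-fold lower number from compound 1 to compound 2 (0.05 log units; within the scatter). Compound 3 `[O-][n+]1nc(NC2CCCC2)[n+]([O-])c2ccc(F)cc21` carries a different core, set apart from compound 1 by fluoro in place of hydrogen on an aromatic carbon; in this assay compound 3 gives 2.3 ug/mL, and the step of a 4.3-fold lower number from compound 1 to compound 3 (0.64 log units; beyond the scatter). Compound 4 `[O-][n+]1nc(NC2CCCCC2)[n+]([O-])c2ccc(F)cc21` has not yet been measured; it differs from compound 3 by cyclohexyl in place of cyclopentyl on a nitrogen on an aromatic ring, the same change already seen once between compound 1 and compound 2, with identical surroundings at the place. Because that earlier step a 1.1-fold lower number from compound 1 to compound 2 (0.05 log units; within the scatter) stayed within the scatter, the expected step here is a 1.1-fold lower number from compound 3 to compound 4 (0.04 log units; within the scatter). Compound 4 is therefore expected to give about 2.1 ug/mL in this assay, most likely between 1 ug/mL and 4.5 ug/mL.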

Compound 4, half-maximal cytotoxic concentration: < 2.5 ug/mL
Compound 4 gave a limit, no number; the forecaster's own chance of this, stated with the estimate: 5%; the middle value lies beyond the limit too.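

In this assay compound 4 gives < 2.5 ug/mL and this is a limit of the assay, not a number, so the step for cyclohexyl in place of cyclopentyl on the core of compound 3 cannot be read. The fluoro change can be read, as an at least 3.5-fold lower number from compound 2 to compound 4 (0.55 log units; beyond the scatter) shows, and it runs the same way with cyclohexyl as with cyclopentyl: the same change on two cores in this assay, a 4.3-fold lower number (0.64 log units; beyond the scatter) from compound 1 to compound 3 and an at least 3.5-fold lower number (0.55 log units; beyond the scatter) from compound 2 to compound 4; the limit leaves it open whether they differ. The direction of the fluoro change therefore carries over in these two pairs, but its size is not pinned down, and nothing is shown about whether the cyclohexyl change carries onto the fluoro core.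

Still open, from the compounds shown here alone, is where compound 4 lies past its limit. Also open, going by these compounds, is how chloro or methoxy in place of fluoro, or a longer chain in place of cyclohexyl, would read in this assay.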